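The source may hold more compounds than are shown below. What is called first, only, known or untested is meant among the compounds shown, and "the series" means these compounds.

Compound 3 `COc1ccc(C(=O)CSc2nnc(-c3cc(OC)c(OC)c(OC)c3)n2N)cc1` is the reference point of this account. For the measured compounds named here, in a functional assay on PC-3 cells (Homo sapiens) for antiproliferative activity, read by MTT assay, with a stated time of 48 h (a higher number here means a weaker inhibitor, a lower number a stronger inhibitor), compound 3 gives 97900 nM, the only plain number among the three measured compounds. Compound 1 `COc1cc(-c2nnc(SCC(=O)c3ccc(Cl)cc3)n2N)cc(OC)c1OC` carries chloro on the aromatic carbon where compound 3 carries methoxy; in this assay compound 1 gives > 100000 nM, which is a limit of the assay and not a number. Compound 2 `COc1cc(-c2nnc(SCC(=O)c3ccc(F)cc3)n2N)cc(OC)c1OC` carries fluoro at that aromatic carbon; in this assay compound 2 gives > 100000 nM, likewise a limit. Both of them thus sit at the limit of > 100000 nM in this assay, at which 2 of the 3 values shown sit. The steps toward compound 3 are an at least 1.0-fold lower number from compound 1 to compound 3 (0.00 log units; that floor lies within the scatter) and an at least 1.0-fold lower number from compound 2 to compound 3 (0.00 log units; that floor lies within the scatter), while the step that the two limits leave unreadable from compound 1 to compound 2.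

Compound 4 `COc1cc(-c2nnc(SCC(=O)Nc3ccccc3F)n2N)cc(OC)c1OC` differs from compound 3 by (2-fluorophenyl)amino in place of 4-methoxyphenyl on a carbonyl carbon. Going by the values given here, none of the measured steps touches the carbonyl carbon or its neighbours; each of them only exchanges one small group on an aromatic carbon, and none of those exchanges moved the numbers beyond the scatter. The measured steps therefore give no guide of their own to this change, and the expected step is a 1.0-fold higher number from compound 3 to compound 4 (0.01 log units; within the scatter), that is, none beyond the scatter. Compound 4 is estimated to give 100000 nM in this assay, with a range from 30000 nM to 300000 nM, and a considerable chance that the assay again reports only a limit.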

Compound 4, half-maximal inhibitory concentration: 36700 nM
Estimate against measurement, compound 4: 2.7-fold (0.44 log units) above, within the range that was stated.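

In this assay the exchange on the carbonyl carbon gives a 2.7-fold lower number from compound 3 to compound 4 (0.43 log units; beyond the scatter) and so moves the number beyond the scatter, which no exchange of one small group on the aromatic carbon had been shown to do. Measured against the two compounds that carry a limit, the same kind of exchange gives an at least 2.7-fold lower number from compound 2 to compound 4 (0.43 log units; beyond the scatter) and also an at least 2.7-fold lower number from compound 1 to compound 4 (0.43 log units; beyond the scatter) and these two steps are floors only, because compound 1 and compound 2 rest on a limit of the assay and not on a number: the limit of > 100000 nM in this assay, at which 2 of the 4 values shown sit. With its steps to all three others printed as beyond the scatter, compound 4 is the most potent of the four shown, and the carbonyl carbon is the one place here where a change has a readable effect, though a modest one.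

This single exchange alters the link to the ring and the ring's substituent together, so the compounds shown do not separate the amino link from the 2-fluoro group. Phenylamino or benzylamino on the same carbonyl carbon would bear on that question, and whether the step would hold in any other assay also remains open.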